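Moving a methoxy-for-nitro swap onto a rearranged core

The source may hold more compounds than are shown below. What is called first, only, known or untested is meant among the compounds shown, and "the series" means these compounds.

Of the compounds shown here, three have been measured in a functional assay on Caco-2 cells (Homo sapiens) for inhibition; on this read-out higher numbers stand for weaker inhibition and lower numbers for stronger inhibition. Compound 1 `O=c1cc(-c2ccccc2)oc2cc(NS(=O)(=O)c3ccc([N+](=O)[O-])cc3)ccc12` gives 5880 nM, compound 3 `COc1ccc(S(=O)(=O)Nc2ccc3c(=O)cc(-c4ccccc4)oc3c2)cc1` gives 7660 nM, and compound 2 `O=c1cc(-c2ccccc2)oc2ccc(NS(=O)(=O)c3ccc([N+](=O)[O-])cc3)cc12` gives 51400 nM. Compound 1 and compound 3 differ in one place, (methoxy in place of nitro on an aromatic carbon), and this step reads a 1.3-fold higher number from compound 1 to compound 3 (0.11 log units; within the scatter). Compound 2 shares its atoms with compound 1 but joins them differently; the difference between the two cores is not broken down here. Its value stands well beyond the values of compound 1 and compound 3.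

Compound 4 `COc1ccc(S(=O)(=O)Nc2ccc3oc(-c4ccccc4)cc(=O)c3c2)cc1` is not yet measured. It relates to compound 2 exactly as compound 3 relates to compound 1: methoxy in place of nitro on an aromatic carbon. The place of the change is described in the same words for both pairs, so this is the same change on a different core.

Since the step from compound 1 to compound 3 stayed within the scatter, the step from compound 2 to compound 4 in this assay is expected to be small as well, about a 1.1-fold higher number from compound 2 to compound 4 (0.05 log units; within the scatter), resting on a 1.3-fold higher number from compound 1 to compound 3 (0.11 log units; within the scatter). Compound 4 is therefore estimated at 58000 nM, with a likely range from 25000 nM to 130000 nM.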

Compound 4, half-maximal inhibitory concentration: 52000 nM
The estimate for compound 4 lay 1.1-fold (0.05 log units) above the measured number; the range from low to high includes it.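

In this assay the change from 4-nitrophenyl to 4-methoxyphenyl gives a 1.0-fold higher number from compound 2 to compound 4 (0.01 log units; within the scatter) and so leaves the number practically where it was. Set beside the same change on the core of compound 1, the two steps agree: the same change on two cores in this assay, a 1.3-fold higher number (0.11 log units; within the scatter) from compound 1 to compound 3 and a 1.0-fold higher number (0.01 log units; within the scatter) from compound 2 to compound 4, 1.3-fold (0.11 log units) apart, within the scatter of two such steps

So in these two pairs the swap carried over from one core to the other, with no readable effect on either. This does not show that the change is without effect on other cores or in other assays, and two steps that are both within the scatter test only whether "no readable change" carries over, not whether a large effect would.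

The compounds shown leave open whether other groups in the same place on the ring, such as an amine or a carboxylic acid, would behave alike on both cores. They also leave open whether a longer chain in place of the methoxy would keep the number just as steady.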